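The source may hold more compounds than are shown below. What is called first, only, known or untested is meant among the compounds shown, and "the series" means these compounds.

Measured so far:
compound 1 `CCCn1c(=O)c2[nH]c(-c3ccc(S(=O)(=O)N4CCN(c5ccc(Cl)cc5)CC4)cc3)nc2n(CC)c1=O`: 24%
compound 2 `CCCn1c(=O)[nH]c2nc(-c3ccc(S(=O)(=O)N4CCN(c5cccc(F)c5)CC4)cc3)[nH]c2c1=O`: 34%
compound 3 `CCCn1c(=O)[nH]c2nc(-c3ccc(S(=O)(=O)N4CCN(c5ccccc5Cl)CC4)cc3)[nH]c2c1=O`: 25%

In an assay on CHO cells for displacement of a labelled ligand from adenosine receptor A1 (Homo sapiens), read by scintillation counting, with a stated time of 90 min, tested at 1 uM, in the presence of a further agent that is not named here (on this read-out higher numbers stand for more inhibition at the one concentration tested (going by the name of the read-out) and lower numbers for less inhibition), compound 2 gives the highest of the three numbers, yet the gap to compound 3, a number 9 percentage points lower from compound 2 to compound 3 (within the scatter), is within the scatter, and compound 1 with 24% is likewise within the scatter of compound 2, so no ordering of the three can be claimed.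

Compound 4 `CCCn1c(=O)[nH]c2nc(-c3ccc(S(=O)(=O)N4CCN(c5cccc(Cl)c5)CC4)cc3)[nH]c2c1=O` differs from compound 2 by chloro in place of fluoro on an aromatic carbon. Within the data shown here, the one measured step that bears on this is the change on the same phenyl ring from compound 2 to compound 3, a number 9 percentage points lower from compound 2 to compound 3 (within the scatter), which stayed within the scatter. On that basis compound 4 is expected to sit close to compound 2, with an expected step of no change at the digits printed from compound 2 to compound 4 (within the scatter), not beyond the scatter. The estimate for compound 4 is 34%, with a range from 20% to 48%.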

Compound 4, a percentage reported as inhibition, at one concentration (the size of the read-out at that concentration, not a potency): 21%
Estimate against measurement, compound 4: 13 percentage points above; the range from low to high includes it.
By their numbers in this assay, from the lowest: compounds 4, 1, 3 and 2 (each within the scatter of the next, the first and the last beyond it).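

In this assay, among these compounds, chloro in place of fluoro on an aromatic carbon, meta to a large group, gives the only step beyond the scatter among the single-change pairs so far, a modest one: a number 13 percentage points lower from compound 2 to compound 4 (beyond the scatter) on this ring. The change to 3-chlorophenyl in place of 2-chlorophenyl, a number 4 percentage points lower from compound 3 to compound 4 (within the scatter), stays within the scatter, so the two chloro placements cannot be told apart. No available evidence bears on the cause of the halogen step. The compounds shown leave open how a methoxy group or an amine would read at this place.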